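Ester and amide chalcones: chain extension on the amide

A few compounds are considered here, and "the series" means these few. Any claim that something is new, unique, unknown or untested is made for them only; others in the source may bear on it.

Measured so far:
compound 1 `CCOC(=O)c1ccc(/C=C/C(=O)c2cc(OC)ccc2OC)cc1` 4490 nM
compound 2 `COc1ccc(OC)c(C(=O)/C=C/c2ccc(C(=O)OC(C)C)cc2)c1` 4420 nM
compound 3 `CCNC(=O)c1ccc(/C=C/C(=O)c2cc(OC)ccc2OC)cc1` 3760 nM

In a functional assay on NTUB1 cells (Homo sapiens) for cytotoxicity, read by MTT assay, with a stated time of 72 h (on this read-out lower numbers stand for stronger inhibition and higher numbers for weaker inhibition), compound 1 gives 4490 nM, compound 2 gives 4420 nM and compound 3 gives 3760 nM. The change methyl in place of hydrogen on a saturated chain carbon bound to an oxygen next to a carbonyl group and a saturated chain carbon made the step of a 1.0-fold lower number from compound 1 to compound 2 (0.01 log units; within the scatter). The cores of compound 1 and compound 3 differ by ethylamino in place of ethoxy on a carbonyl carbon, with the step of a 1.2-fold lower number from compound 1 to compound 3 (0.08 log units; within the scatter).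

Compound 4 `CCCNC(=O)c1ccc(/C=C/C(=O)c2cc(OC)ccc2OC)cc1` is not yet measured. It differs from compound 3 by methyl in place of hydrogen on a saturated chain carbon, two bonds along the chain from an amide-type nitrogen, the same kind of change as from compound 1 to compound 2, but its place is a saturated chain carbon two bonds along the chain from an amide-type nitrogen rather than one bound to an oxygen next to a carbonyl group. Because a 1.0-fold lower number from compound 1 to compound 2 (0.01 log units; within the scatter) sat within the scatter, compound 4 is expected to sit close to compound 3, with the estimated step of a 1.1-fold lower number from compound 3 to compound 4 (0.06 log units; within the scatter). For compound 4 the estimate in this assay is 3300 nM, expected between 1800 nM and 6500 nM.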

Compound 4, half-maximal inhibitory concentration: 2260 nM
Compound 4: the middle estimate sits 1.5-fold (0.16 log units) above what was measured; the range from low to high includes it.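

In this assay the added methyl gives a 1.7-fold lower number from compound 3 to compound 4 (0.22 log units; within the scatter), and this step agrees with the one on the ester: the same change on two cores in this assay, a 1.0-fold lower number (0.01 log units; within the scatter) from compound 1 to compound 2 and a 1.7-fold lower number (0.22 log units; within the scatter) from compound 3 to compound 4, 1.6-fold (0.21 log units) apart, within the scatter of two such steps. The exchanges of ester for propylamino, a 2.0-fold lower number from compound 2 to compound 4 (0.29 log units; within the scatter) and a 2.0-fold lower number from compound 1 to compound 4 (0.30 log units; within the scatter), also stay within the scatter, so the ester and amide compounds shown are not separated. Going by these compounds alone, with all these steps within the scatter and only two cores compared, the agreement shows that the change is neutral within the scatter here, not that it has a real effect or that it would carry to a further core.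

Still open, on these data alone, is whether a longer chain such as butylamino would give a step beyond the scatter. The same applies to a free carboxylic acid in place of the ester.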